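The compounds below may be only part of what the source reports. "The series", "measured", "known", "first", "only" and "open" are said of these compounds alone.

Measured compounds:
Compound 1 `C[C@H](Nc1ncnc2[nH]cnc12)c1cc2ccc(F)cn2c(=O)c1-c1ccccc1` gives 95% in an ADME assay on microsomes from liver (Rattus norvegicus), read by LC-MS, using NADPH, with a stated time of 30 min, tested at 1 uM; a lower number here means that less of the compound is left, a higher number that more of the compound is left.
Compound 2 `C[C@H](Nc1ccnc(N)n1)c1cc2ccc(F)cn2c(=O)c1-c1ccccc1` is reported as "not determined" (no result reported) in this assay.
Compound 3 `Cc1nc(N)c(C#N)c(N[C@@H](C)c2cc3ccc(F)cn3c(=O)c2-c2ccccc2)n1` is reported as "not determined" (no result reported) in this assay.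

Compound 3 therefore stands nowhere on the numbers shown: one further compound, compound 2, also lacks a value, and only compound 1 provides a figure. Compound 4 `Cc1nc(N)nc(N[C@@H](C)c2cc3ccc(F)cn3c(=O)c2-c2ccccc2)c1C#N` differs from compound 3 by 2-amino-5-cyano-6-methylpyrimidin-4-yl in place of 6-amino-5-cyano-2-methylpyrimidin-4-yl on an amine nitrogen, so the two carry the same atoms joined differently. Within the data shown here, no step between measured compounds exists to size this change; since the atoms are unchanged, the author expects no step beyond the usual scatter in this assay between compound 3 and compound 4. Resting only on compound 1, compound 4 is expected to show 80%, within 50% to 100%.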

Compound 4, percent of the compound remaining: 41%
Compound 4: middle estimate off by 39 percentage points, on the high side; measured number below the stated range.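

In this assay, the group on the amine nitrogen proves able to move the read-out strongly: 2-amino-5-cyano-6-methylpyrimidin-4-yl in place of the group of compound 1 gives a number 54 percentage points lower from compound 1 to compound 4 (beyond the scatter) on the shared core. Among these compounds, this is the first sign that this position matters, as a single earlier figure could show no such range. Nothing at hand explains the drop.

Steps involving compound 2 or compound 3 cannot be read, so the effect of rearranging the pyrimidine's amino and methyl groups stays unknown. Going by these compounds, whether a plain phenyl or a pyridine on this nitrogen would fall nearer compound 1 or compound 4 also remains open.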